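The compounds below may be only part of what the source reports. "The series", "measured", "known", "first", "only" and "open" are said of these compounds alone.

For the measured compounds named here, in a functional assay on MCF7 cells (Homo sapiens) for inhibition, read by MTT assay, with a stated time of 48 h (a higher number here means a weaker inhibitor, a lower number a stronger inhibitor), two compounds built on a shared core have numbers so far. Compound 1 (`CCOC(=O)C1=C(NN=C(C(C)=O)C(C)=O)Nc2[nH]nc(C)c2C1c1ccc(N(C)C)cc1`) gives 9740 nM, and compound 2 (`CCOC(=O)C1=C(N/N=C(/Cl)c2ccc([N+](=O)[O-])cc2)Nc2[nH]nc(C)c2C1c1ccc(N(C)C)cc1`) gives 52700 nM, the higher of the two numbers, which makes it the weaker inhibitor of this pair. Compound 3 (`CCOC(=O)C1=C(N/N=C(/Br)c2ccccc2)Nc2[nH]nc(C)c2C1c1ccc(N(C)C)cc1`) has not yet been measured. It differs from compound 2 by a group of 9 heavy atoms (7 carbon, 1 nitrogen, 1 bromine; one six-membered aromatic ring of carbon only) in place of a group of 12 heavy atoms (7 carbon, 2 nitrogen, 2 oxygen, 1 chlorine; one six-membered aromatic ring of carbon only), on an amine nitrogen. Going by the values given here, only one measured step bears on this change: a 5.4-fold higher number from compound 1 to compound 2 (0.73 log units; beyond the scatter), a modest step that also falls on an amine nitrogen. In that step a group of 12 heavy atoms replaced a group of 8 heavy atoms and the number rose, whereas here a group of 9 heavy atoms replaces the group of 12 heavy atoms. That step also brought in a six-membered aromatic ring of carbon only, which both groups here contain, so it offers only a loose guide. A small move towards a lower number is therefore expected, and the expected change is a 2.2-fold lower number from compound 2 to compound 3 (0.34 log units; beyond the scatter). For compound 3 the estimated value is 24000 nM, with an expected range from 9000 nM to 65000 nM.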

Compound 3, half-maximal inhibitory concentration: 78400 nM
Compound 3: middle estimate off by 3.3-fold (0.51 log units), on the low side; measured number outside the range, above it.
By their numbers in this assay, from the lowest: compound 1; then compounds 2 and 3 (each within the scatter of the next).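

In this assay, exchanging the group of 12 heavy atoms for the group of 9 heavy atoms on the amine nitrogen gives a 1.5-fold higher number from compound 2 to compound 3 (0.17 log units; within the scatter), so this change separates neither the two groups nor the two compounds that carry them. For the compounds shown here, the earlier rise from the ringless group of 8 heavy atoms was seen with only one ring-bearing group, and the second such group now shows the same direction, with an 8.0-fold higher number from compound 1 to compound 3 (0.91 log units; beyond the scatter), which leaves compound 1 with the lowest number of the three. No measurement is offered here that would account for these numbers.

The group that leaves and the group that enters differ at once in their halogen, chlorine against bromine, and in the rest of their atoms, so the compounds shown cannot say what either difference does alone. Also open, going by these compounds, is whether a group with a six-membered aromatic ring of carbon only can ever reach the number of compound 1, for instance one bearing an amine or a carboxylic acid, and whether a longer ringless chain would hold that number.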